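Indol-2-yl in place of 2-phenylethenyl: an expected step

The source may hold more compounds than are shown below. What is called first, only, known or untested is meant among the compounds shown, and "the series" means these compounds.

Compound 1, `CC(=O)Oc1ccc2cc(-n3cc(-c4ccc(C)cc4)nn3)c(=O)oc2c1C`, in a functional assay on MCF7 cells (Homo sapiens) for antiproliferative activity (on this read-out higher numbers stand for weaker inhibition and lower numbers for stronger inhibition), gives > 100000 nM, a limit of the assay.
Compound 2, `COc1ccc(-c2cn(-c3cc4ccc(OC(C)=O)c(C)c4oc3=O)nn2)cc1`, in this assay gives > 100000 nM, again a limit.
Compound 3, `CC(=O)Oc1ccc2cc(-n3cc(/C=C/c4ccccc4)nn3)c(=O)oc2c1C`, in this assay gives 28500 nM.

Going by the values given here, compound 3 thus stands as the only compound of the three with a number rather than a limit, and both measured steps lead to it: an at least 3.5-fold lower number from compound 1 to compound 3 (0.54 log units; beyond the scatter) and an at least 3.5-fold lower number from compound 2 to compound 3 (0.54 log units; beyond the scatter). Both steps replace a six-membered aryl group by 2-phenylethenyl at the same place, and both are at least modest, their exact size hidden by the limit (the limit of > 100000 nM in this assay, at which 2 of the 3 values shown sit).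

Compound 4, `CC(=O)Oc1ccc2cc(-n3cc(-c4cc5ccccc5[nH]4)nn3)c(=O)oc2c1C`, is not yet measured. The change from compound 3 is 1H-indol-2-yl in place of 2-phenylethenyl on an aromatic carbon. Among the compounds with values here, no measured step exchanges 2-phenylethenyl for a bicyclic group, so the two steps above show only that the group at this position matters and that a number below the limit is reachable. Compound 4 is therefore expected to sit near compound 3, with a step of a 1.2-fold higher number from compound 3 to compound 4 (0.09 log units; within the scatter) not clearly beyond the scatter. The estimate for compound 4 in this assay is 35000 nM, within 7000 nM to 150000 nM, with a real chance that only a limit is reported.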

Compound 4, half-maximal inhibitory concentration: 76100 nM
The estimate for compound 4 lay 2.2-fold (0.34 log units) below the measured number; low and high end bracket the measured number.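

In this assay, going by these compounds alone, putting 1H-indol-2-yl in place of 2-phenylethenyl on this aromatic carbon gives a 2.7-fold higher number from compound 3 to compound 4 (0.43 log units; beyond the scatter), the first step at this place whose size can be read in full. It shows that a second group can give a number rather than a limit, but also that the two groups are not interchangeable, and compound 3 remains the strongest of the four compounds. Compared with the two six-membered aryl groups, the new group gives an at least 1.3-fold lower number from compound 2 to compound 4 (0.11 log units; that floor lies within the scatter) and an at least 1.3-fold lower number from compound 1 to compound 4 (0.11 log units; that floor lies within the scatter), and these floors alone do not separate compound 4 from either compound, as the true sizes of both steps remain hidden: the limit of > 100000 nM in this assay, at which 2 of the 4 values shown sit.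

The compounds shown leave open whether the lower number of compound 3 depends on the double bond outside aromatic rings, which 2-phenylethyl at the same place would test. They also leave open whether the hydrogen on the indole nitrogen matters, as 1-methylindol-2-yl would show, and whether an amine or a carboxylic acid on the phenyl ring of 2-phenylethenyl would move the number in either direction.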